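Chloro added between ring nitrogens on the fused core

A few compounds are considered here, and "the series" means these few. Any claim that something is new, unique, unknown or untested is made for them only; others in the source may bear on it.

Working notes on a short set of benzyl-substituted fused cores. Compound 1 `ClCc1ccc(Cn2cnc3ncnc(Cl)c32)cc1` is the parent of the pair under review. For compound 1 the record in a functional assay on SK-MEL-28 cells (Homo sapiens) for cytotoxicity, read by sulforhodamine B assay, with a stated time of 48 h (on this read-out lower numbers stand for stronger inhibition of growth and higher numbers for weaker inhibition of growth), reads "not determined" (no result reported), so no single number places it on the potency scale. Going by the values given here, the only measured member is compound 2 `ClCc1cccc(Cn2cnc3ncnc(Cl)c32)c1`, which carries the chloromethyl group on a different position of the benzyl ring; in this assay compound 2 gives 3540 nM. Among the compounds with values here, no step between two measured compounds is available, and the two isomers are not linked by any recorded difference.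

Compound 3 `ClCc1ccc(Cn2cnc3nc(Cl)nc(Cl)c32)cc1` is derived from compound 1 by the change (chloro in place of hydrogen on an aromatic carbon). Within the data shown here, with no measured step to lean on, the expectation in this assay is for a shift from compound 1 to compound 3 of no more than the usual scatter, with no clear direction. Taking the result of compound 2 as the only anchor for this core, compound 3 is estimated at 3000 nM, with a range from 800 nM to 12000 nM.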

Compound 3, concentration for total growth inhibition: 5120 nM
Compound 3: middle estimate off by 1.7-fold (0.23 log units), on the low side, within the range that was stated.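

In this assay, going by these compounds alone, compound 3 gives 5120 nM and compound 1 has no single number, so no step from compound 1 to compound 3 can be read. Whether chloro in place of hydrogen on the core of compound 1 shifts growth inhibition, and in which direction, stays open with the compounds shown. No supporting data bear on this result.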